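Biaryl replacement for a benzylsulfanyl arm on the core

The source may report more compounds than this note shows. Statements on the series, on what has been measured and on what is new or still open speak of the compounds shown alone.

Compound 1 `CCC1CCN(c2cc(C(F)(F)F)ccc2CNC(=O)C(C)c2ccc(NS(C)(=O)=O)c(F)c2)CC1`: 0.7 nM
Compound 2 `COc1ccc(CSc2cc(C(F)(F)F)ccc2CNC(=O)C(C)c2ccc(NS(C)(=O)=O)c(F)c2)cc1`: 2.3 nM

Of the compounds shown here, two have been measured in an assay on CHO cells for antagonist activity at transient receptor potential cation channel subfamily V member 1 (Homo sapiens), read by FLIPR; on this read-out lower numbers stand for stronger inhibition and higher numbers for weaker inhibition. Compound 1 gives 0.7 nM in this assay, and compound 2 gives 2.3 nM in this assay. Among the measured compounds shown here, the one step between them, a 3.3-fold higher number from compound 1 to compound 2 (0.52 log units; beyond the scatter), comes with the exchange of the 4-ethylpiperidin-1-yl group for the (4-methoxybenzyl)sulfanyl group on an aromatic carbon. Compound 2 therefore stands with the higher of the two numbers.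

Compound 3 `CC(C(=O)NCc1ccc(C(F)(F)F)cc1-c1ccc(C(C)(C)C)cc1)c1ccc(NS(C)(=O)=O)c(F)c1` has not yet been measured. It differs from compound 2 in one place: 4-(tert-butyl)phenyl in place of (4-methoxybenzyl)sulfanyl on an aromatic carbon. For the measured compounds named here, no measured step changes this same group in the same way, so the only guide is the step from compound 1 to compound 2, which shows that a change at this position moves the number only modestly. Compound 3 is therefore expected to remain close to compound 2, with a step of a 1.1-fold higher number from compound 2 to compound 3 (0.04 log units; within the scatter) in this assay, which is within the scatter. The estimate for compound 3 is 2.5 nM in this assay, with a range from 0.6 nM to 10 nM.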

Compound 3, inhibition constant: 1.1 nM
The estimate for compound 3 lay 2.3-fold (0.36 log units) above the measured number, within the range that was stated.
By their numbers in this assay, from the lowest: compounds 1 and 3 (each within the scatter of the next); then compound 2.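

In this assay, the step of a 2.1-fold lower number from compound 2 to compound 3 (0.32 log units; beyond the scatter) shows that on this aromatic carbon, ortho to a large group and meta to a trifluoromethyl group, an arm holding no oxygen or sulfur can replace (4-methoxybenzyl)sulfanyl and give a lower number, although both arms have 10 heavy atoms and one six-membered aromatic ring of carbon only. The second step, a 1.6-fold higher number from compound 1 to compound 3 (0.20 log units; within the scatter), places 4-(tert-butyl)phenyl level with 4-ethylpiperidin-1-yl, so these two quite different arms cannot be told apart in this read-out, and the position holds the number with either of them. Nothing available here accounts for either step.

The exchange from compound 2 to compound 3 alters the sulfur-linked benzyl connection and the outer substituent together, so the two changes remain unseparated, and a 4-methoxyphenyl group or a (4-tert-butylbenzyl)sulfanyl group at this position would be needed to part them. Going by these compounds, it also remains open whether the number would hold with a carboxylic acid or a primary amine on the outer ring in place of the tert-butyl group.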